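This account rests on a few compounds, and the source may have more. Where it says the series, first, only, none or still open, it means among the compounds named here.

Measured in a functional assay on HT-1080 cells (Homo sapiens) for antiproliferative activity, read by MTT assay, with a stated time of 72 h; on this read-out higher numbers stand for weaker inhibition and lower numbers for stronger inhibition:
- compound 1 `CCOC(=O)c1cc(-c2cc(OC)c(OC)c(OC)c2)c(-c2ccc(OC)c(O)c2)s1`: 3220 nM
- compound 2 `COc1ccc(-c2sc(C(=O)O)cc2-c2cc(OC)c(OC)c(OC)c2)cc1OCc1ccccc1`: > 100000 nM (a limit of the assay, not a number)

Within the data shown here, compound 2 stands at the assay limit, with > 100000 nM as its only reading. Compound 1 gives a true number, 3220 nM.

Compound 3 `COc1ccc(-c2sc(C(=O)O)cc2-c2cc(OC)c(OC)c(OC)c2)cc1O` differs from compound 2 by one change: hydrogen in place of benzyl on an oxygen on an aromatic ring. In words, hydrogen takes the place of benzyl on an oxygen on an aromatic ring, so benzyloxy becomes hydroxy.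

Among the measured compounds shown here, no measured step covers this change, so its size can only be estimated. The expected step of an at least 2.5-fold lower number from compound 2 to compound 3 (0.39 log units; beyond the scatter) is a modest strengthening of inhibition at best, and the read-out may again return only a limit. For the measured compounds named here, compound 1, at 3220 nM, is the sole number available, and compound 3 is expected to stay on the weaker side of it. The estimate for compound 3 is 40000 nM, with an expected range of 10000 nM to 100000 nM.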

Compound 3, half-maximal inhibitory concentration: 7510 nM
Compound 3: the middle estimate sits 5.3-fold (0.73 log units) above what was measured; measured number below the stated range.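

In this assay, the oxygen on the aromatic ring proves to be a sensitive place in this series: benzyloxy to hydroxy gives an at least 13-fold lower number from compound 2 to compound 3 (1.12 log units; beyond the scatter), and the carboxylic acid series now has a true number. The size of this step is open-ended, since compound 2 stands at a limit of the assay and not at a number: the limit of > 100000 nM in this assay, at which 1 of the 3 values shown sits.

With the hydroxy kept, hydrogen in place of ethyl on an oxygen next to a carbonyl group gives a 2.3-fold higher number from compound 1 to compound 3 (0.37 log units; beyond the scatter), a modest step beside the large one at the aromatic oxygen.

Going by these compounds, how benzyloxy reads when the ethyl ester is present remains open. Also open, on these data alone, is whether an ethoxy group or an amine in the place of the hydroxy would hold the number or lose it.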